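Replacing the Sulfonamide Acid Tail in Compound 1

A few compounds are considered here, and "the series" means these few. Any claim that something is new, unique, unknown or untested is made for them only; others in the source may bear on it.

Measured so far:
compound 1, `CCCCN(C(=O)c1ccc(C(F)(F)F)cc1)c1nnc(-c2ccc(S(=O)(=O)NCCC(=O)O)cc2)s1`: 13.8 uL/min
compound 2, `CCCCN(C(=O)c1ccc(C(F)(F)F)cc1)c1nnc(-c2cccc3c2ccn3CCC(=O)O)s1`: 119 uL/min

Compound 1 `CCCCN(C(=O)c1ccc(C(F)(F)F)cc1)c1nnc(-c2ccc(S(=O)(=O)NCCC(=O)O)cc2)s1` carries a (2-carboxyethyl)sulfamoyl group on its outer ring. In an ADME assay on microsomes from liver (Homo sapiens) for metabolic stability, read by LC-MS, tested at 0.5 uM (on this read-out higher numbers stand for fast clearance and lower numbers for slow clearance), compound 1 gives 13.8 uL/min, the lowest of the two numbers measured. Compound 2 `CCCCN(C(=O)c1ccc(C(F)(F)F)cc1)c1nnc(-c2cccc3c2ccn3CCC(=O)O)s1`, built on the same core but with a different ring system, gives in this assay 119 uL/min, a number that lies beyond the usual scatter above that of compound 1.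

Compound 3 `CCCCN(C(=O)c1ccc(C(F)(F)F)cc1)c1nnc(-c2ccc(CN(C)C)cc2)s1` is the next compound to be measured. It differs from compound 1 in one place: (dimethylamino)methyl in place of (2-carboxyethyl)sulfamoyl on an aromatic carbon. Within the data shown here, no pair of measured compounds shows this same change, so its effect cannot be read from a step already seen.

For compound 3 the expectation is that the number in this assay rises beyond the scatter, with an estimated step of a 4.0-fold higher number from compound 1 to compound 3 (0.60 log units; beyond the scatter) from compound 1. The estimated value for compound 3 is 55 uL/min, with a range from 18 uL/min to 170 uL/min.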

Compound 3, intrinsic clearance in a liver preparation (reported as CLH), per the amount of preparation that the assay uses: 109 uL/min
Estimate against measurement, compound 3: 2.0-fold (0.30 log units) below; low and high end bracket the measured number.
By their numbers in this assay, from the lowest: compound 1; then compounds 3 and 2 (each within the scatter of the next).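

In this assay, putting (dimethylamino)methyl in place of (2-carboxyethyl)sulfamoyl on this aromatic carbon, para to a large group, gives a 7.9-fold higher number from compound 1 to compound 3 (0.90 log units; beyond the scatter). Among these compounds, this is the first change at a single place that can be read here, and it shows that the low number of compound 1 is not set by the shared core alone: with the rest of the molecule held the same, exchanging this one group moves the read-out beyond the usual scatter. Several things change together, as the group that leaves has 9 heavy atoms and 2 hydrogen-bond donors while the group that enters has 4 heavy atoms and 0 hydrogen-bond donors, and nothing measured here ties the rise to any one of these differences.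

On these data alone, it remains open whether a plain sulfamoyl group, without the carboxyethyl chain, or a carboxymethyl group on the same carbon would give a number close to that of compound 1 or close to that of compound 3. Also open, as far as these compounds go, is whether a longer chain such as (dimethylamino)ethyl would behave like (dimethylamino)methyl in this assay.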